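The compounds below may be only part of what the source reports. "The series", "measured", "known", "first", "only" and "open" are said of these compounds alone.

Two members of the series have been measured in an assay on CHO cells for displacement of a labelled ligand from prostaglandin E2 receptor EP1 subtype (Homo sapiens) (on this read-out higher numbers stand for weaker inhibition and lower numbers for stronger inhibition), so far. Compound 1 `CCOc1ccc(Cc2nnc(CN(c3ccccc3CC)S(=O)(=O)c3ccc(C)cc3)o2)cc1` gives 126 nM in this assay. Compound 2 `COc1ccc(Cc2nnc(CN(c3cccc(C(F)(F)F)c3C)S(=O)(=O)c3ccc(C)cc3)o2)cc1` gives 63.1 nM in this assay, the lower of the two numbers, though the gap to compound 1 falls within the scatter, so no order between them can be read.

Compound 3 `COc1ccc(Cc2nnc(CN(c3cccc(Cl)c3Cl)S(=O)(=O)c3ccc(C)cc3)o2)cc1` is not yet measured. It differs from compound 2 in one place: 2,3-dichlorophenyl in place of 2-methyl-3-(trifluoromethyl)phenyl on a sulfonamide nitrogen. The substitution pattern of the ring on the sulfonamide nitrogen is kept; only the identity of the two groups changes.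

For the measured compounds named here, no step between measured compounds touches this position, so nothing in the data shows how this assay responds to it. The expectation is a step in this assay of about a 1.3-fold higher number from compound 2 to compound 3 (0.10 log units; within the scatter), which is no change beyond the scatter. Compound 3 is therefore estimated at 80 nM in this assay, with a range from 30 nM to 250 nM.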

Compound 3, half-maximal inhibitory concentration: 7.94 nM
For compound 3 the middle estimate is 10-fold (1.00 log units) above the measured one; the whole stated range lies above it.
By their numbers in this assay, from the lowest: compound 3; then compounds 2 and 1 (each within the scatter of the next).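

In this assay, for the compounds shown here, the aryl group on the sulfonamide nitrogen proves to be a responsive position: 2,3-dichlorophenyl in place of 2-methyl-3-(trifluoromethyl)phenyl gives a 7.9-fold lower number from compound 2 to compound 3 (0.90 log units; beyond the scatter), the only step so far and one beyond the scatter. The substitution pattern is kept in this change, so the step goes with the identity of the two groups and not with their pattern. No available data bear on why the step has this size.

From the compounds shown here alone, both groups change at once here, so it remains open whether one chlorine or the pair accounts for the step. Also open, going by these compounds, is how the position responds to other groups on this ring, such as bromine, a nitrile or a ring bearing both chlorine and methyl.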